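The compounds below may be only part of what the source reports. "The series", "measured", "known", "first", "only" and "open" are said of these compounds alone.

Measured so far:
compound 1, `CN(CCC#N)C[C@H]1CN(c2ccc(-n3cc(-c4ccccn4)cn3)c(F)c2)C(=O)O1` — 1.9
compound 2, `CCC(=O)NC[C@H]1CN(c2ccc(-n3cc(-c4ccccn4)cn3)c(F)c2)C(=O)O1` — 2.2

Both compounds share one core and differ only in the group on a saturated chain carbon bound to a saturated ring carbon. In a physicochemical assay for lipophilicity, read by HPLC, measured as octanol-water partition (a higher number here means a more lipophilic compound, a lower number a more polar compound), compound 1 gives 1.9 and compound 2 gives 2.2. Among the measured compounds shown here, the single measured step, a number 0.30 log units higher from compound 1 to compound 2 (within the scatter), lies within the scatter, so compound 2 stands at the higher of the two numbers without being separable from compound 1.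

Compound 3, `NC(=O)[C@H]1CN(c2ccc(-n3cc(-c4ccccn4)cn3)c(F)c2)C(=O)O1`, has not been measured. It differs from compound 2 by carbamoyl in place of (propanoylamino)methyl on a saturated ring carbon.

For the measured compounds named here, no measured step covers this change: the one step in hand swaps groups on the chain carbon, whereas here the whole (propanoylamino)methyl side chain gives way to a carbamoyl group on the ring carbon itself. That step is therefore no guide to size, and the expectation rests on the structural change alone. The larger group leaves and the smaller one enters, so a drop beyond the scatter is expected in this assay, amounting to an estimated step of a number 0.90 log units lower from compound 2 to compound 3 (beyond the scatter). Compound 3 is expected near 1.3, with an estimated range from 0.8 to 1.8.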

Compound 3, partition coefficient: 1.59
Beside the measured number, compound 3's estimate is 0.29 log units below it, and the stated range covers the measured number.
By their numbers in this assay, from the lowest: compound 3; then compounds 1 and 2 (each within the scatter of the next).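

Among the compounds shown here, on the saturated ring carbon next to the ring oxygen, carbamoyl in place of (propanoylamino)methyl gives, in this assay, the first step that clears the scatter, a number 0.61 log units lower from compound 2 to compound 3 (beyond the scatter), with the heavy atoms going from 6 to 3 while the count of 1 hydrogen-bond donor and 1 hydrogen-bond acceptor stays the same. The step of a number 0.31 log units lower from compound 1 to compound 3 (beyond the scatter), for carbamoyl in place of ((2-cyanoethyl)(methyl)amino)methyl, also lies beyond the scatter, so the position separates carbamoyl from two differently built side chains that remain within the scatter of each other. Nothing available gives a reason for the size of either step.

The compounds shown leave open whether these steps follow the number of heavy atoms or the loss of the chain carbon that links the amide to the ring, a question that a carbamoylmethyl group on the same ring carbon would address. On these data alone, how an aminomethyl group, a carboxylic acid or a longer acylamino chain would read at this position also remains open.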